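Compound 3 to compound 4: a 4-fluorophenyl exchange

The source may report more compounds than this note shows. Statements on the series, on what has been measured and on what is new or still open speak of the compounds shown alone.

In a functional assay on HT-29 cells (Homo sapiens) for inhibition, read by MTT assay, with a stated time of 3 days (a higher number here means a weaker inhibitor, a lower number a stronger inhibitor), compound 1 `COc1ccc(COc2cc(/C=C\c3cc(OC)c(OC)c(OC)c3)ccc2OC)cc1` gives 47000 nM, compound 2 `COCOc1ccccc1/C=C/CCCOc1cc(/C=C\c2cc(OC)c(OC)c(OC)c2)ccc1OC` gives 9600 nM and compound 3 `COCOc1cccc(/C=C/CCCOc2cc(/C=C\c3cc(OC)c(OC)c(OC)c3)ccc2OC)c1` gives 59000 nM. Compound 3 and compound 1 thus lie within the scatter of each other, and both stand clearly higher than compound 2. Compound 4 `COc1ccc(/C=C\c2cc(OC)c(OC)c(OC)c2)cc1OCCC/C=C/c1ccc(F)cc1` is still unmeasured, and the change leading to it is 4-fluorophenyl in place of 3-(methoxymethoxy)phenyl on a double-bonded chain carbon bound to a double-bonded chain carbon. The methoxymethoxy group is gone, and the new ring sits on the same double-bonded chain carbon. Within the data shown here, the one measured step at this place is a 6.1-fold higher number from compound 2 to compound 3 (0.79 log units; beyond the scatter), modest but beyond the scatter. It exchanged 2-(methoxymethoxy)phenyl for 3-(methoxymethoxy)phenyl, so it shows that this place can shift the number but gives no direction for 4-fluorophenyl. A modest move toward a lower number is expected, within the span from compound 2 at 9600 nM to compound 3 at 59000 nM. The expected step is a 2.4-fold lower number from compound 3 to compound 4 (0.37 log units; beyond the scatter). For compound 4 the estimated value is 25000 nM, with an expected range from 7000 nM to 70000 nM.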

Compound 4, half-maximal inhibitory concentration: 98000 nM
The estimate for compound 4 lay 3.9-fold (0.59 log units) below the measured number, and the stated range ends below it.
By their numbers in this assay, from the lowest: compound 2; then compounds 1, 3 and 4 (each within the scatter of the next, the first and the last beyond it).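

In this assay the exchange gives a 1.7-fold higher number from compound 3 to compound 4 (0.22 log units; within the scatter) and so does not separate 4-fluorophenyl from 3-(methoxymethoxy)phenyl at this place, even though the methoxymethoxy group is gone. Set against the other ring, the same place shows a 10-fold higher number from compound 2 to compound 4 (1.01 log units; beyond the scatter) and is now the largest step here, which leaves compound 2 alone among the three chain-bearing compounds, with compounds 3 and 4 both beyond the scatter from it. The comparison with the shorter substituent reads a 2.1-fold higher number from compound 1 to compound 4 (0.32 log units; beyond the scatter) for 4-(4-fluorophenyl)but-3-en-1-yl in place of 4-methoxyphenyl, so this chain with its fluorinated ring offers no gain over compound 1. Nothing at hand explains any of these steps. On these data alone, whether the standing of compound 2 belongs to the methoxymethoxy group itself or to where it sits remains open. So does what a hydroxyl or an amine on this ring would give.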